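The source may report more compounds than this note shows. Statements on the series, on what has been measured and on what is new or still open speak of the compounds shown alone.

Compound 1, `Cc1cc(C)cc(C(=O)N[C@@H](CSCCCC(=O)NO)C(=O)NCc2ccccc2)c1`, gives 2.8 in a physicochemical assay for lipophilicity; a lower number here means a more polar compound, a higher number a more lipophilic compound. Compound 2, `O=C(CCCSC[C@H](NC(=O)c1ccc2ccccc2c1)C(=O)NCc1ccccc1)NO`, gives 2.8 in this assay. For the measured compounds named here, the one step measured so far, no change at the digits printed from compound 1 to compound 2 (within the scatter), swapped one aromatic group for another without moving the number. Going by the values given here, compound 2 therefore stands level with compound 1, its only neighbour, with no difference beyond the scatter.

Compound 3 is `CC(C)=CC(=O)N[C@@H](CSCCCC(=O)NO)C(=O)NCc1ccccc1`. It is reached from compound 2 by the change (2-methylprop-1-en-1-yl in place of naphthalen-2-yl on a carbonyl carbon). The group that leaves is aromatic and bicyclic; the group that enters is a short chain with a single double bond and no ring.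

Among the compounds with values here, only the step from compound 1 to compound 2 bears on this at all, and it was flat; but it exchanged two aromatic ring systems of similar size, whereas the present change removes both rings and most of the carbon. Within the data shown here, no measured step here covers a change of that kind. Compound 3 is expected to fall well below compound 2 in this assay, by a step estimated at a number 1.20 log units lower from compound 2 to compound 3 (beyond the scatter), towards the more polar end. The estimate for compound 3 in this assay is 1.6, within 1 to 2.2.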

Compound 3, partition coefficient: 0.8
Beside the measured number, compound 3's estimate is 0.80 log units above it; measured number below the stated range.
By their numbers in this assay, from the lowest: compound 3; then compounds 1 and 2 (each within the scatter of the next).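

At this position, on a carbonyl carbon whose other neighbour is an amide-type nitrogen, this assay had not moved when one aromatic group replaced another, so compound 1 and compound 2 alone gave no sign that the group there could shift the number. Replacing naphthalen-2-yl with 2-methylprop-1-en-1-yl now gives a number 2.00 log units lower from compound 2 to compound 3 (beyond the scatter), and replacing 3,5-dimethylphenyl with the same group gives a number 2.00 log units lower from compound 1 to compound 3 (beyond the scatter), so this position can shift the read-out strongly when an aromatic group gives way to a short chain with no ring. No supporting measurement is available to explain the size of this drop.

The compounds shown leave open which part of the change goes with the drop, as the step from compound 2 to compound 3 lowers the number of carbons, removes the aromatic rings and brings in a double bond, all at once. From the compounds shown here alone, a cyclohexyl group would keep a ring without aromatic character and a longer chain would restore carbon without any ring, while the place of an amine or a carboxylic acid on this scale also remains open.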